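A smaller aryl group on the shared core

This account rests on a few compounds, and the source may have more. Where it says the series, first, only, none or still open, it means among the compounds named here.

Measured compounds:
compound 1 `C[C@H](c1ccc(C(=O)NCCC(=O)O)cc1)N1C(=O)C(c2cccc(C3CC3)c2)=N[C@]12CC[C@@H](C(C)(C)C)CC2` gives 340 nM
compound 2 `CC(C)(C)CC[C@H](c1ccc(C(=O)NCc2nn[nH]n2)cc1)N1C(=O)C(c2cncc(Cl)c2)=N[C@]12CC[C@@H](C(C)(C)C)CC2` gives 480 nM
compound 3 `CC(C)(C)CC[C@H](c1ccc(C(=O)NCc2nn[nH]n2)cc1)N1C(=O)C(c2cccc(C(F)(F)F)c2)=N[C@]12CC[C@@H](C(C)(C)C)CC2` gives 180 nM

In a functional assay on CHO cells for antagonist activity at Glucagon receptor (Homo sapiens), read by cAMP accumulation, with stated times of 30 min and 45 min (a higher number here means a weaker inhibitor, a lower number a stronger inhibitor), compound 3 has the lowest of the three numbers. Compound 1 lies within the scatter of compound 3, so the two cannot be told apart; compound 2 lies beyond it. Compound 4 `CC(C)(C)CC[C@H](c1ccc(C(=O)NCc2nn[nH]n2)cc1)N1C(=O)C(c2ccc(F)cc2)=N[C@]12CC[C@@H](C(C)(C)C)CC2` has not yet been measured. It differs from compound 3 by one change: 4-fluorophenyl in place of 3-(trifluoromethyl)phenyl on a carbon with a double bond to nitrogen.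

Among the compounds with values here, only one measured step touches the same position, the change of the aryl group on the carbon with a double bond to nitrogen: a 2.7-fold lower number from compound 2 to compound 3 (0.43 log units; beyond the scatter). That step shows that swapping this aryl group moves the number modestly, and the 3-(trifluoromethyl)phenyl of compound 3 gave the lower number. A move to a different aryl group is therefore expected to shift the number again by a modest amount, more likely upward than downward, though nothing measured shows 4-fluorophenyl itself.

Compound 4 is expected to give 320 nM in this assay, within 120 nM to 850 nM, a step of a 1.8-fold higher number from compound 3 to compound 4 (0.25 log units; within the scatter).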

Compound 4, half-maximal inhibitory concentration: 240 nM
The estimate for compound 4 lay 1.3-fold (0.12 log units) above the measured number, and the stated range covers the measured number.
By their numbers in this assay, from the lowest: compounds 3, 4, 1 and 2 (each within the scatter of the next, the first and the last beyond it).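

In this assay, this position does not separate 4-fluorophenyl from 3-(trifluoromethyl)phenyl: the step is a 1.3-fold higher number from compound 3 to compound 4 (0.12 log units; within the scatter), so the group with fewer heavy atoms and a single fluorine serves as well here as the larger one. Compound 4 also cannot be told apart from the chloropyridine compound, with a step of a 2.0-fold lower number from compound 2 to compound 4 (0.30 log units; within the scatter), so the one clear gap among these three aryl groups remains a 2.7-fold lower number from compound 2 to compound 3 (0.43 log units; beyond the scatter), and a single aryl swap at this position may move the number only a little. No measurement offered here explains these numbers.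

On these data alone, whether an aryl group bearing an amine or a carboxylic acid would keep the number in this range remains open. So does the effect of a saturated ring such as cyclohexyl in place of the aryl group.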